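Removing a Protecting Group from a Stilbene Antiproliferative

The compounds below may be only part of what the source reports. "The series", "measured", "known", "first", "only" and "open" are said of these compounds alone.

Of the compounds shown here, two sharing one core have been tested in a functional assay on HeLa cells (Homo sapiens) for antiproliferative activity, read by CCK-8 assay, with a stated time of 48 h; a lower number here means a stronger inhibitor, a higher number a weaker inhibitor. Compound 1 `COc1ccc(/C=C\c2cc(OC)c(OC)c(OC)c2)cc1OCc1ccc(C=O)cc1` carries an aldehyde on its outer ring, and in this assay compound 1 gives 4800 nM. Compound 2 `COc1ccc(/C=C\c2cc(OC)c(OC)c(OC)c2)cc1OCc1ccc(CN2CCCCC2C(=O)NCCNC(=O)OC(C)(C)C)cc1` instead carries a longer side chain ending in a protected amine, and in this assay compound 2 gives 2000 nM. Of the two numbers, compound 2 has the lower one, and the gap to compound 1 lies beyond the usual scatter, so compound 2 is the stronger inhibitor of the pair.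

Compound 3 `COc1ccc(/C=C\c2cc(OC)c(OC)c(OC)c2)cc1OCc1ccc(CN2CCCCC2C(=O)NCCN)cc1` is compound 2 with one change: hydrogen in place of tert-butoxycarbonyl on an amine nitrogen. The protecting group is simply gone, leaving the free amine on the chain.

For the measured compounds named here, no measured pair shows what this kind of change does on this core, so the expectation rests on compound 2 alone. The free amine is expected to land near its parent, with a step from compound 2 to compound 3 in this assay of about a 1.3-fold lower number from compound 2 to compound 3 (0.12 log units; within the scatter), perhaps a small move toward a lower number, but not clearly beyond the scatter. For compound 3 the estimate in this assay is 1500 nM, with a plausible range from 500 nM to 5000 nM.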

Compound 3, half-maximal inhibitory concentration: 7300 nM
For compound 3 the middle estimate is 4.9-fold (0.69 log units) below the measured one; measured number outside the range, above it.
By their numbers in this assay, from the lowest: compound 2; then compounds 1 and 3 (each within the scatter of the next).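

In this assay the end of the side chain turns out to matter, since hydrogen in place of tert-butoxycarbonyl on an amine nitrogen gives a 3.7-fold higher number from compound 2 to compound 3 (0.56 log units; beyond the scatter) in the direction of a weaker inhibitor. For the compounds shown here, this is the first change at a single place on the shared core that can be read, and it shows that this position is not indifferent to what it carries: of this pair, the protected compound 2 is the stronger inhibitor, and the step lies beyond the usual scatter. No measurement shown here accounts for the loss, so the step stands as an observation without a known cause.

Going by these compounds, it remains open whether other groups on this nitrogen, such as an acetyl group, a methyl group or a benzyl carbamate, would stay close to compound 2 or fall closer to compound 3. Also open, on these data alone, is whether a longer chain ending in the same free amine, or a carboxylic acid in place of that amine, would move the number in either direction.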